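Capping a phenol oxygen with methyl

This account rests on a few compounds, and the source may have more. Where it says the series, first, only, none or still open, it means among the compounds named here.

Compound 1 `O=C(NCCCNc1cc(-c2cn(-c3ccccc3)nc2-c2cccc(O)c2)ccn1)Nc1ccc(F)cc1` gives 6280 nM
Compound 2 `O=C(NCCCNc1cc(-c2cn(-c3ccccc3)nc2-c2cccc(O)c2)ccn1)Nc1cccc(C(F)(F)F)c1` gives 8720 nM

Within the data shown here, in a functional assay on COLO 205 cells (Homo sapiens) for antiproliferative activity, read by sulforhodamine B assay, with a stated time of 48 h (on this read-out lower numbers stand for stronger inhibition of growth and higher numbers for weaker inhibition of growth), compound 1 sits within the scatter of compound 2, its only comparison: the step is a 1.4-fold higher number from compound 1 to compound 2 (0.14 log units; within the scatter) and shows no real separation. Compound 3 `COc1cccc(-c2nn(-c3ccccc3)cc2-c2ccnc(NCCCNC(=O)Nc3ccc(F)cc3)c2)c1` differs from compound 1 by methyl in place of hydrogen on an oxygen on an aromatic ring and so turns 3-hydroxyphenyl into 3-methoxyphenyl. Among the measured compounds shown here, that measured step concerns another part of the molecule, and no measured step covers this oxygen, so the direction stays open and no step beyond the scatter is expected in this assay for now. The expected step is a 1.2-fold higher number from compound 1 to compound 3 (0.08 log units; within the scatter) and remains only an estimate. Compound 3 is estimated at 7500 nM with an expected range from 3000 nM to 20000 nM in this wide first guess.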

Compound 3, concentration for total growth inhibition: 29300 nM
Compound 3: middle estimate off by 3.9-fold (0.59 log units), on the low side; measured number outside the range, above it.
By their numbers in this assay, from the lowest: compounds 1 and 2 (each within the scatter of the next); then compound 3.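

Among these compounds, putting methyl on the phenol oxygen is the first change here to move the number beyond the scatter: in this assay, a 4.7-fold higher number from compound 1 to compound 3 (0.67 log units; beyond the scatter) means weaker inhibition of growth. So 3-hydroxyphenyl to 3-methoxyphenyl does matter at this position, a point the earlier swap on the amide-type nitrogen could not show. Nothing available explains why the number rises. On these data alone, it remains open whether an amine or an ethoxy group in this place would behave like hydroxy or like methoxy. As far as these compounds go, it also remains open whether methyl has the same effect when 3-(trifluoromethyl)phenyl replaces 4-fluorophenyl.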